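Ester-to-amide swap at the aryl carbonyl

The source may hold more compounds than are shown below. What is called first, only, known or untested is meant among the compounds shown, and "the series" means these compounds.

Compounds measured so far:
- compound 1 `COc1ccc(COCC(Cn2ccnc2)OCc2ccc(OC)cc2)cc1`: 9900 nM
- compound 2 `CCCCCCCCOC(=O)c1ccc(COC(COCc2ccc(OC)cc2)Cn2ccnc2)cc1`: 21000 nM

Within the data shown here, in a functional assay for inhibition of Thromboxane-A synthase (Homo sapiens) (a lower number here means a stronger inhibitor, a higher number a weaker inhibitor), compound 2 gives the higher of the two numbers; the only other entry is compound 1, and the step of a 2.1-fold higher number from compound 1 to compound 2 (0.33 log units; beyond the scatter) is modest. Compound 3 `CCNC(=O)c1ccc(COC(COCc2ccc(OC)cc2)Cn2ccnc2)cc1` differs from compound 2 by ethylamino in place of octyloxy on a carbonyl carbon. Among the measured compounds shown here, no measured pair shares this change; the sole step available, a 2.1-fold higher number from compound 1 to compound 2 (0.33 log units; beyond the scatter), touched the same position and was small, so a small step is anticipated. For compound 3 the expected value in this assay is 12000 nM (range 4000 nM to 40000 nM), an estimated step of a 1.8-fold lower number from compound 2 to compound 3 (0.24 log units; within the scatter).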

Compound 3, half-maximal inhibitory concentration: 12400 nM
Estimate against measurement, compound 3: 1.0-fold (0.01 log units) below; measured number inside the range.
By their numbers in this assay, from the lowest: compounds 1, 3 and 2 (each within the scatter of the next, the first and the last beyond it).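

In this assay, ethylamino in place of octyloxy on the carbonyl carbon gives a 1.7-fold lower number from compound 2 to compound 3 (0.23 log units; within the scatter), and ethylcarbamoyl in place of methoxy on the aromatic carbon gives a 1.3-fold higher number from compound 1 to compound 3 (0.10 log units; within the scatter). The ethylcarbamoyl compound therefore lies within the scatter of both the methoxy and the octyloxycarbonyl compounds, so this position tolerates an amide without a step beyond the scatter. No available evidence explains these numbers.

This change alters both the linkage and the chain length, so an octyl amide or ethyl ester would be needed to separate them. As far as these compounds go, a carboxylic acid at this position also remains open.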